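Compound 4: a new benzyl group at the assay's edge

This account rests on a few compounds, and the source may have more. Where it says the series, first, only, none or still open, it means among the compounds named here.

Of the compounds shown here, three sharing one core have been tested in a functional assay on B16 cells (Mus musculus) for antiproliferative activity, with a stated time of 72 h; on this read-out higher numbers stand for weaker inhibition and lower numbers for stronger inhibition. Compound 1 `OC[C@H]1O[C@@H](n2cnc3c(NCc4ccccc4Cl)ncnc32)[C@H](O)[C@@H]1O` gives > 166000 nM, which is a limit and not a number. Compound 2 `OC[C@H]1O[C@@H](n2cnc3c(NCc4ccc(F)cc4Cl)ncnc32)[C@H](O)[C@@H]1O` gives > 166000 nM, again a limit. Among the measured compounds shown here, compound 3 `OC[C@H]1O[C@@H](n2cnc3c(NCc4ccc(F)c(Cl)c4)ncnc32)[C@H](O)[C@@H]1O` gives 167000 nM, the only true number among them. The record therefore holds (the limit of > 166000 nM in this assay, at which 2 of the 3 values shown sit).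

Compound 4 `Cc1cccc(CNc2ncnc3c2ncn3[C@@H]2O[C@H](CO)[C@@H](O)[C@H]2O)c1O` keeps the shared core but carries 2-hydroxy-3-methylphenyl in place of 3-chloro-4-fluorophenyl on a saturated chain carbon bound to a nitrogen on an aromatic ring. For the measured compounds named here, two measured steps bear on this change, a step that the limit leaves unreadable from compound 1 to compound 3 and a step that the limit leaves unreadable from compound 2 to compound 3. Going by the values given here, neither gives a size to carry over, and no measured compound holds the entering group, so the forecast is loose.

Compound 3 stands at 167000 nM. A step toward weaker inhibition would probably leave no readable number, so a moderate step toward stronger inhibition is the readable outcome expected. The expected change is a 5.6-fold lower number from compound 3 to compound 4 (0.75 log units; beyond the scatter). For compound 4 the estimated value is 30000 nM, with an expected range from 4000 nM to 167000 nM.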

Compound 4, half-maximal inhibitory concentration: > 166000 nM
Compound 4: a limit, no number; the forecaster's own chance of this, stated with the estimate: 30%; at least 5.5-fold (0.74 log units) between middle value and limit.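

In this assay, among the compounds shown here, compound 4 gives only a limit, so no step linking it to compound 1, compound 2 or compound 3 can be read, because the record now holds this: the limit of > 166000 nM in this assay, at which 3 of the 4 values shown sit. The compounds shown leave open whether any benzyl group on the shared core can give a readable number clearly lower than that of compound 3.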